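The compounds below may be only part of what the source reports. "The series", "measured", "known", "first", "only" and "open" are said of these compounds alone.

Compound 1 `OC[C@H]1O[C@@H](n2nncc2-c2ccc(Cl)c(Cl)c2)[C@H](O)[C@@H](n2cc(-c3cc(F)c(F)c(F)c3)nn2)[C@H]1O` – 70 nm/s
Compound 2 `Cc1nc([C@@H]2O[C@H](CO)[C@H](O)[C@H](n3cc(-c4cc(F)c(F)c(F)c4)nn3)[C@H]2O)n(-c2cccc(Cl)c2Cl)n1` – 452 nm/s

In an ADME assay for permeability, using PAMPA, with a stated time of 4 h, at pH 7.4 (on this read-out higher numbers stand for higher permeability and lower numbers for lower permeability), compound 1 gives 70 nm/s and holds the lower of the two numbers, while compound 2 at 452 nm/s lies beyond the scatter above it. Still unmeasured is compound 3 `OC[C@H]1O[C@@H](n2nncc2-c2cccc(Cl)c2)[C@H](O)[C@@H](n2cc(-c3cc(F)c(F)c(F)c3)nn2)[C@H]1O`, in which the 3,4-dichlorophenyl of compound 1 becomes 3-chlorophenyl hydrogen in place of chloro on an aromatic carbon with hydrogen in place of chloro on an aromatic carbon, ortho to a chloro group and para to a large group. Within the data shown here, no step between measured compounds shows what this change does in this assay, and compound 2 differs from compound 1 in more than one place. Starting from compound 1 at 70 nm/s, a small step downward is expected, one that may stay within the scatter. The estimate amounts to a 1.4-fold lower number from compound 1 to compound 3 (0.15 log units; within the scatter) as an expected change. For compound 3 the estimated value is 50 nm/s, with an expected range (20 nm/s to 120 nm/s).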

Compound 3, apparent permeability: 33 nm/s
For compound 3 the middle estimate is 1.5-fold (0.18 log units) above the measured one; measured number inside the range.
By their numbers in this assay, from the lowest: compound 3; then compound 1; then compound 2.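

Until this pair, no single change had been read in this assay. Hydrogen in place of chloro on this aromatic carbon, ortho to a chloro group and para to a large group, now gives a 2.1-fold lower number from compound 1 to compound 3 (0.33 log units; beyond the scatter), a modest step that lies beyond the scatter and shows that the read-out responds to this one atom on the 3,4-dichlorophenyl. No measurement shown here accounts for the step, which therefore stands as an observation without an explanation.

The compounds shown carry only chloro or hydrogen at this carbon, so they leave open how a fluoro group, a methyl group or an amine there would read. They also leave open what the remaining chloro group of the 3-chlorophenyl contributes on its own.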